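The source may hold more compounds than are shown below. What is called first, only, known or untested is meant among the compounds shown, and "the series" means these compounds.

Working notes on the series. Two compounds have numbers in an ADME assay on cells (Macrophage, Homo sapiens) for cytotoxicity, read by MTT assay, with a stated time of 24 h; a lower number here means that less compound is tolerated, a higher number that more compound is tolerated. Compound 1 `CC(O)Cn1c([N+](=O)[O-])cnc1/C=C/c1ccccc1` gives 1500 nM in this assay, and compound 2 `COc1ccccc1/C=C/c1ncc([N+](=O)[O-])n1CC(C)O` gives 480 nM. Within the data shown here, on those two numbers compound 2 stands lowest, and the only measured step, a 3.1-fold lower number from compound 1 to compound 2 (0.49 log units; beyond the scatter), is the one that separates it from compound 1.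

Compound 3 `CC(O)Cn1c([N+](=O)[O-])cnc1/C=C/c1ccccc1Br` is not yet measured. Relative to compound 2 the change is bromo in place of methoxy on an aromatic carbon, on an aromatic carbon of a six-membered aromatic ring of carbon only. Among the measured compounds shown here, no measured step swaps bromo for methoxy here; the only step that bears on the site, from compound 1 to compound 2, was modest and went toward a lower number. With one substituent again present at that carbon, a number near compound 2, or somewhat back toward compound 1, is expected, so the expected step is a 1.6-fold higher number from compound 2 to compound 3 (0.19 log units; within the scatter). For compound 3 the estimate in this assay is 750 nM, within 250 nM to 2200 nM.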

Compound 3, half-maximal cytotoxic concentration: 490 nM
Beside the measured number, compound 3's estimate is 1.5-fold (0.18 log units) above it; measured number inside the range.
By their numbers in this assay, from the lowest: compounds 2 and 3 (each within the scatter of the next); then compound 1.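

In this assay, the exchange of methoxy for bromo on this aromatic carbon, ortho to a large group, gives a 1.0-fold higher number from compound 2 to compound 3 (0.01 log units; within the scatter), so the two groups cannot be told apart here even though one heavy atom and the one hydrogen-bond acceptor of methoxy are gone. Bromo in place of hydrogen gives a 3.1-fold lower number from compound 1 to compound 3 (0.49 log units; beyond the scatter), matching a 3.1-fold lower number from compound 1 to compound 2 (0.49 log units; beyond the scatter), so the lower number seen with compound 2 is not specific to methoxy and appears with both substituents shown at this carbon. Nothing available bears on why these two groups give numbers within the scatter of each other.

On these data alone, whether an amine, a carboxylic acid or a longer chain at this carbon would also fall with compound 2 and compound 3 remains open. Also open, as far as these compounds go, is whether bromo or methoxy at another carbon of the ring would give the same lower number.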